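Series notes: from compound 3 to compound 4

The compounds below may be only part of what the source reports. "The series", "measured", "known", "first", "only" and "open" are said of these compounds alone.

In an ADME assay on CHO cells (Cricetulus griseus) for cytotoxicity, read by MTT assay, with a stated time of 72 h (on this read-out higher numbers stand for lower toxicity in this test and lower numbers for higher toxicity in this test), compound 3 `CCOC(=O)c1c(-c2ccc(OC)cc2)oc2ccc(OCCCCN3C(=O)C(=O)c4ccccc43)cc12` gives 256000 nM, level with compound 1 `CCOC(=O)c1c(-c2ccc(F)cc2)oc2ccc(OCCCN3C(=O)C(=O)c4ccccc43)cc12` at 256000 nM. Compound 2 `CCOC(=O)c1c(-c2ccc(OC)cc2)oc2ccc(OCCCN3C(=O)C(=O)c4cc(F)ccc43)cc12` lies lower, at 64000 nM. The structural change to compound 4 `CCOC(=O)c1c(-c2ccc(OC)cc2)oc2ccc(OCCCCCN3C(=O)C(=O)c4ccccc43)cc12` is a group of 12 heavy atoms (9 carbon, 1 nitrogen, 2 oxygen; one five-membered non-aromatic ring with 1 hetero atom, one six-membered aromatic ring of carbon only) in place of a group of 11 heavy atoms (8 carbon, 1 nitrogen, 2 oxygen; one five-membered non-aromatic ring with 1 hetero atom, one six-membered aromatic ring of carbon only), on a saturated chain carbon, four bonds along the chain from an oxygen on an aromatic ring. Neither group carries a net charge. Within the data shown here, only one measured step bears on this change: a 4.0-fold higher number from compound 2 to compound 3 (0.60 log units; beyond the scatter). That step is modest and also removes a fluorine-bearing group, so it is only a partial guide. Among the measured compounds shown here, no measured step isolates the present change. No step beyond the scatter is therefore expected in this assay. The estimated step is a 1.2-fold lower number from compound 3 to compound 4 (0.07 log units; within the scatter). For compound 4 the estimated value is 220000 nM, with an expected range from 64000 nM to 512000 nM.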

Compound 4, half-maximal cytotoxic concentration: 128000 nM
The estimate for compound 4 lay 1.7-fold (0.24 log units) above the measured number; the measured number falls inside the stated range.
By their numbers in this assay, from the lowest: compounds 2, 4, 1 and 3 (each within the scatter of the next, the first and the last beyond it).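

In this assay, the group of 12 heavy atoms in place of the group of 11 heavy atoms, on a saturated chain carbon, four bonds along the chain from an oxygen on an aromatic ring, gives a 2.0-fold lower number from compound 3 to compound 4 (0.30 log units; within the scatter). Unlike the earlier step, this exchange involves no fluorine, and it shows that this change alone stays within the scatter in this test. No supporting evidence bears on this result. From the compounds shown here alone, whether a longer chain, or an amine or carboxylic acid at this place, would also stay within the scatter remains open.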